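The source may report more compounds than this note shows. Statements on the series, on what has been measured and on what is new or still open speak of the compounds shown alone.

Measured so far in a functional assay on HeLa cells (Homo sapiens) for antiproliferative activity, read by CCK-8 assay, with a stated time of 72 h; a lower number here means a stronger inhibitor, a higher number a weaker inhibitor:
Compound 1, `Cc1ccc(C(=O)Nc2cccc(-c3oc4cc(-c5ccc(F)cc5)ccc4c(=O)c3O)c2)cc1`, gives 6190 nM.
Compound 2, `O=C(Nc1cccc(-c2oc3cc(-c4ccc(F)cc4)ccc3c(=O)c2O)c1)c1ccc(Cl)cc1`, gives 3670 nM.
Compound 3, `N#Cc1ccc(C(=O)Nc2cccc(-c3oc4cc(-c5ccc(F)cc5)ccc4c(=O)c3O)c2)cc1`, gives 23300 nM.

Compound 2 has the lowest of these three numbers. Compound 1 sits within the scatter of it, the step being a 1.7-fold lower number from compound 1 to compound 2 (0.23 log units; within the scatter), while compound 3 is clearly weaker, as a 6.3-fold higher number from compound 2 to compound 3 (0.80 log units; beyond the scatter) shows. Compound 4, `CCCc1ccc(C(=O)Nc2cccc(-c3oc4cc(-c5ccc(F)cc5)ccc4c(=O)c3O)c2)cc1`, differs from compound 2 in one place: propyl in place of chloro on an aromatic carbon. Going by the values given here, no measured step places a propyl group on this carbon, so only indirect evidence bears on it. Swapping methyl for chloro moved the number only within the scatter (a 1.7-fold lower number from compound 1 to compound 2 (0.23 log units; within the scatter)), whereas cyano gave a modest loss in both a 3.8-fold higher number from compound 1 to compound 3 (0.58 log units; beyond the scatter) and a 6.3-fold higher number from compound 2 to compound 3 (0.80 log units; beyond the scatter). Of the groups measured, methyl is the nearest relative of propyl, and methyl and chloro were indistinguishable here, so no step beyond the scatter is expected from compound 2 to compound 4 in this assay, with a slightly higher number the more likely drift. Compound 4 is therefore estimated at 5000 nM, with a range from 2000 nM to 13000 nM. That estimate means an expected step of a 1.4-fold higher number from compound 2 to compound 4 (0.13 log units; within the scatter).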

Compound 4, half-maximal inhibitory concentration: 8790 nM
For compound 4 the middle estimate is 1.8-fold (0.25 log units) below the measured one, and the stated range covers the measured number.
By their numbers in this assay, from the lowest: compounds 2, 1 and 4 (each within the scatter of the next, the first and the last beyond it); then compound 3.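

In this assay, lengthening the methyl of compound 1 to the propyl of compound 4 gives no change that can be told from the scatter (a 1.4-fold higher number from compound 1 to compound 4 (0.15 log units; within the scatter)), so this position accepts the longer chain about as well as it accepts methyl. Chloro and propyl, however, can be told apart (a 2.4-fold higher number from compound 2 to compound 4 (0.38 log units; beyond the scatter)), although chloro and methyl could not, and the step from the nitrile shows that compound 3 remains the weakest of the four (a 2.7-fold lower number from compound 3 to compound 4 (0.42 log units; beyond the scatter)). Nothing shown here accounts for these differences.

From the compounds shown here alone, it remains open whether a longer chain such as pentyl, or a branched one such as tert-butyl, would stay level with compound 4. How an amine or a carboxylic acid on this aromatic carbon would compare with chloro is equally unsettled.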